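Nitro substitution on the benzamide ring of a thienopyridine series

This account rests on a few compounds, and the source may have more. Where it says the series, first, only, none or still open, it means among the compounds named here.

Measured so far:
compound 1, `NC(=O)c1c(NC(=O)c2ccc(C(F)(F)F)cc2)sc2c1CCN(Cc1ccc(Cl)cc1)C2`, a functional assay on MKN-74 cells (Homo sapiens) for antiproliferative activity, with a stated time of 24 h; on this read-out higher numbers stand for weaker inhibition and lower numbers for stronger inhibition: > 50000 nM
compound 2, `NC(=O)c1c(NC(=O)c2ccccc2Cl)sc2c1CCN(C(=S)Nc1c(Cl)cccc1Cl)C2`, this assay: 4020 nM
compound 3, `NC(=O)c1c(NC(=O)c2ccccc2)sc2c1CCN(C(=S)Nc1ccccc1Cl)C2`, this assay: 11800 nM

Compound 1 gives only a limit of the assay, not a number (the limit of > 50000 nM in this assay, at which 1 of the 3 values shown sits). Compound 3 carries the unsubstituted benzoyl on the amide and stands at the highest of the two numbers; compound 2 sits lower, beyond the scatter, and compound 2 differs from compound 3 in more than one place, so only the two values themselves can be compared.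

Compound 4, `NC(=O)c1c(NC(=O)c2cccc([N+](=O)[O-])c2)sc2c1CCN(C(=S)Nc1ccccc1Cl)C2`, is the compound yet to be measured. It differs from compound 3 in one place: nitro in place of hydrogen on an aromatic carbon. The group sits on an aromatic carbon of the six-membered carbon ring, meta to a large group, so that the phenyl becomes 3-nitrophenyl.

Among the measured compounds shown here, no single-change step is known in this set, so the expected size of the step from compound 3 to compound 4 in this assay rests on the change alone. A modest shift is expected, with no clear direction beyond the scatter, as the step of a 1.3-fold lower number from compound 3 to compound 4 (0.12 log units; within the scatter) expresses. For compound 4 the estimated value in this assay is 9000 nM, expected to lie between 2500 nM and 32000 nM.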

Compound 4, half-maximal inhibitory concentration: 8850 nM
Estimate against measurement, compound 4: 1.0-fold (0.01 log units) above, and the stated range covers the measured number.
By their numbers in this assay, from the lowest: compound 2; then compounds 4 and 3 (each within the scatter of the next). At a limit, above all of these: compound 1.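

In this assay the piece now has its first comparison of compounds that differ in one place, and a 1.3-fold lower number from compound 3 to compound 4 (0.12 log units; within the scatter) shows that the two compounds stay within the scatter of each other. Putting nitro in place of hydrogen on an aromatic carbon of the benzoyl group, meta to a large group, therefore gives a 3-nitrophenyl compound that this read-out cannot tell apart from its unsubstituted phenyl partner, although the change adds three heavy atoms and two hydrogen-bond acceptors. No measurement shown here gives a reason for this result.

Among the compounds shown here, this single comparison covers only one group at one place, so it remains open whether an amine or a carboxylic acid on the same aromatic carbon would also stay within the scatter of compound 3, or whether nitro would do so elsewhere on the ring. As far as these compounds go, it also remains open which of the several differences between compound 2 and compound 3 goes with the lower number of compound 2.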